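Chloro in Place of Fluoro on Two Related Cores

A few compounds are considered here, and "the series" means these few. Any claim that something is new, unique, unknown or untested is made for them only; others in the source may bear on it.

Compound 1 `O=C(CCCCCCN1C(=O)/C(=N\O)c2cc(F)ccc21)NO` and compound 2 `O=C(CCCCCCN1C(=O)/C(=N\O)c2cc(Cl)ccc21)NO` share one core and differ in a single place. In a functional assay on SW-620 cells (Homo sapiens) for antiproliferative activity, read by sulforhodamine B assay, with a stated time of 48 h (on this read-out lower numbers stand for stronger inhibition and higher numbers for weaker inhibition), compound 1 gives 110 nM, while compound 2 gives 650 nM. The change between them is chloro in place of fluoro on an aromatic carbon, and the step it made is a 5.9-fold higher number from compound 1 to compound 2 (0.77 log units; beyond the scatter).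

Compound 3 `CO/N=C1/C(=O)N(CCCCCCC(=O)NO)c2ccc(F)cc21` carries a second core; the difference between the core of compound 1 and the core of compound 3 is not broken down here. In this assay compound 3 gives 1110 nM, the highest of the three numbers, beyond the scatter from compound 1 but within the scatter of compound 2.

Compound 4 `CO/N=C1/C(=O)N(CCCCCCC(=O)NO)c2ccc(Cl)cc21` has not yet been measured. It differs from compound 3 by chloro in place of fluoro on an aromatic carbon, the same change as that from compound 1 to compound 2, at the same place on the ring. Within the data shown here, compound 4 is therefore expected to lie on the weaker side of compound 3, since the only measured instance of this change, a 5.9-fold higher number from compound 1 to compound 2 (0.77 log units; beyond the scatter), ran that way. The step expected from compound 3 to compound 4 is a 4.5-fold higher number from compound 3 to compound 4 (0.65 log units; beyond the scatter), held somewhat smaller than the measured one because a single step, seen on a different core and from a higher starting number, is a thin basis. In this assay compound 4 is estimated at 5000 nM, with a likely range from 1800 nM to 14000 nM.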

Compound 4, half-maximal inhibitory concentration: 490 nM
The estimate for compound 4 lay 10-fold (1.01 log units) above the measured number, and the stated range ends above it.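

In this assay, chloro in place of fluoro on an aromatic carbon now gives a 2.3-fold lower number from compound 3 to compound 4 (0.36 log units; beyond the scatter), so the change that raised the number on the core of compound 1 lowers it on the second core. Direction and size both depend on the core here: the same change on two cores in this assay, a 5.9-fold higher number (0.77 log units; beyond the scatter) from compound 1 to compound 2 and a 2.3-fold lower number (0.36 log units; beyond the scatter) from compound 3 to compound 4, 13-fold (1.13 log units) apart, beyond the scatter of two such steps. In this series, then, the step measured on one core did not carry over to the other, and the sign of the change could not be taken across. What this does not show is which feature of the two cores is responsible or why the steps part, and it rests on a single pair per core in a single assay, so it sets no general rule for either core.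

The compounds shown leave open whether a third halogen, bromo, on the same aromatic carbon would follow the order seen on each core, or whether the split between the two cores would persist with a hydrogen at that carbon as the point of reference. They also leave open whether the same opposition would hold with a longer chain ending in the hydroxamic acid.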